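Swapping Bromo for Methyl on a Benzoate Ester

A few compounds are considered here, and "the series" means these few. Any claim that something is new, unique, unknown or untested is made for them only; others in the source may bear on it.

- Compound 1 `COc1ccccc1C(=O)O[C@@H]1C[C@H](C)CC[C@H]1C(C)C`: 4.57
- Compound 2 `CC(C)[C@@H]1CC[C@@H](C)C[C@H]1OC(=O)c1ccccc1Br`: 5.61

Both values come from a physicochemical assay for lipophilicity, measured as octanol-water partition; a lower number here means a more polar compound, a higher number a more lipophilic compound. Compound 2 stands higher of the two, at 5.61, well clear of the scatter.

Compound 3 `Cc1ccccc1C(=O)O[C@@H]1C[C@H](C)CC[C@H]1C(C)C` keeps the shared core and changes one group: methyl in place of bromo on an aromatic carbon. This puts methyl in place of bromo on an aromatic carbon, ortho to a large group.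

For the measured compounds named here, only one measured step bears on this change, and it is a large one at the same aromatic carbon: a number 1.04 log units higher from compound 1 to compound 2 (beyond the scatter). Going by the values given here, it shows that a swap there can move this assay beyond the scatter, but no measured compound carries methyl, so the size remains uncertain. Compound 3 is expected to land lower than compound 2 yet higher than compound 1. The expected change is a number 0.36 log units lower from compound 2 to compound 3 (beyond the scatter). For compound 3 the estimate is 5.25, with an expected range from 4.9 to 5.6.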

Compound 3, partition coefficient: 5.29
Estimate against measurement, compound 3: 0.04 log units below, and the stated range covers the measured number.
By their numbers in this assay, from the lowest: compound 1; then compound 3; then compound 2.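

With methyl now measured, three groups can be compared at this one aromatic carbon on the shared core, and in this assay all three stand apart beyond the scatter, rising from methoxy through methyl to bromo. The number moves a number 0.32 log units lower from compound 2 to compound 3 (beyond the scatter) and so the change from bromo to methyl gives back the smaller part of the earlier gap, while the number also moves a number 0.72 log units higher from compound 1 to compound 3 (beyond the scatter) and so the larger part of that gap remains. Methyl and bromo match in heavy atom count and in having no hydrogen-bond donors or acceptors, so these counts alone do not settle the number at this position.

No measured evidence here explains the order of the three groups. From the compounds shown here alone, whether an amine or a carboxylic acid at this carbon would fall below methoxy remains open.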